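Chloro to methyl on the pendant aryl of two cores

The source may hold more compounds than are shown below. What is called first, only, known or untested is meant among the compounds shown, and "the series" means these compounds.

Measured so far:
compound 1 `Cc1nn(C)c2c1C(c1cccc(Cl)c1)=NCCN2CCCN(C)C` — > 10 mg/kg
compound 2 `Cc1nn(C)c2c1C(c1cccc(Cl)c1)=NC(C)(C)CN2` — 2.5 mg/kg
compound 3 `Cc1cccc(C2=NCCN(CCCN(C)C)c3c2c(C)nn3C)c1` — > 10 mg/kg

All values come from a functional assay on the whole organism for positive allosteric modulation, with Rattus norvegicus as the target; on this read-out higher numbers stand for an effect only at larger amounts of compound and lower numbers for an effect already at smaller amounts. Compound 1 gives > 10 mg/kg in this assay, which is a limit of the assay and not a number. Compound 3 likewise gives > 10 mg/kg, again a limit and not a number. Among the measured compounds shown here, compound 2 is the only compound with a number in this assay, at 2.5 mg/kg; the other two values sit at the limit of > 10 mg/kg in this assay, at which 2 of the 3 values shown sit.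

Compound 3 differs from compound 1 by methyl in place of chloro on an aromatic carbon. The step that the two limits leave unreadable from compound 1 to compound 3 cannot be read, since both ends are limits. The difference between the core of compound 1 and the core of compound 2 is not broken down here.

Compound 4 `Cc1cccc(C2=NC(C)(C)CNc3c2c(C)nn3C)c1` is not yet measured in this assay. It differs from compound 2 by methyl in place of chloro on an aromatic carbon, the same change as from compound 1 to compound 3, at the same place. For the measured compounds named here, the only measured instance of this change gives no readable size, so the step from compound 2 to compound 4 has no direct precedent to lean on; the expectation rests on the value of compound 2, 2.5 mg/kg, and on the small size of the swap.

The expected step is a 2.0-fold higher number from compound 2 to compound 4 (0.30 log units; within the scatter). For compound 4 in this assay the estimate is 5 mg/kg, with a likely range from 1.5 mg/kg to 15 mg/kg, and a real chance that only a limit is reported.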

Compound 4, minimum effective dose: > 10 mg/kg
Compound 4 ended at the assay's limit; the forecaster's own chance of this, stated with the estimate: 40%; middle value at least 2.0-fold (0.30 log units) from the limit.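

In this assay, methyl in place of chloro on the aromatic carbon gives an at least 4.0-fold higher number from compound 2 to compound 4 (0.60 log units; beyond the scatter), so on the core of compound 2 the 3-chlorophenyl group cannot be swapped for 3-methylphenyl without a step beyond the scatter. Among the compounds shown here, this is the only readable instance of the change: on the core of compound 1 the same swap cannot be read, since compound 1 and compound 3 both end at a limit, and the series therefore gives no evidence that the step carries over from one core to the other, nor that it fails to. The size of the step is also open upward and only its smallest possible value is known, because compound 4 ends at a limit of the assay and not at a number, as do compound 1 and compound 3: the limit of > 10 mg/kg in this assay, at which 3 of the 4 values shown sit.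

Still open, on these data alone, is whether another group at the same place on the core of compound 2, such as fluoro, methoxy or nitrile, would keep a number in this assay. The compounds shown also leave open whether any aryl group gives a number on the core of compound 1, which carries the dimethylaminopropyl chain.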